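The source may hold more compounds than are shown below. What is called first, only, known or untested is meant among the compounds shown, and "the series" means these compounds.

In an ADME assay on HEK293 cells (Homo sapiens) for cytotoxicity, read by MTT assay, with a stated time of 72 h (on this read-out higher numbers stand for weaker inhibition and lower numbers for stronger inhibition), the measured compounds are:

Compound 1, `O=C(CN1CCN(C(=O)c2cccc(Br)c2)CC1)N1CCN(CCCc2c[nH]c3ccccc23)CC1`: 80700 nM
Compound 2, `O=C(CN1CCN(C(=O)c2cccc(F)c2)CC1)N1CCN(CCCc2c[nH]c3ccccc23)CC1`: 182000 nM
Compound 3, `O=C(CN1CCN(C(=O)c2cccc(Br)c2)CC1)N1CCN(CCCc2c[nH]c3ccc(F)cc23)CC1`: 40600 nM

Compound 2 differs from compound 1 by fluoro in place of bromo on an aromatic carbon, and this change brought a 2.3-fold higher number from compound 1 to compound 2 (0.35 log units; beyond the scatter). Compound 3 differs from compound 1 by fluoro in place of hydrogen on an aromatic carbon, and here a 2.0-fold lower number from compound 1 to compound 3 (0.30 log units; within the scatter).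

Compound 4, `O=C(CN1CCN(C(=O)c2cccc(F)c2)CC1)N1CCN(CCCc2c[nH]c3ccc(F)cc23)CC1`, has not yet been measured. It differs from compound 3 by fluoro in place of bromo on an aromatic carbon. This is the same change that led from compound 1 to compound 2, made on the core of compound 3 rather than that of compound 1; the two cores differ by the fluoro on the indole told above.

A step of about the size seen earlier is therefore expected here, because the earlier step gave a 2.3-fold higher number from compound 1 to compound 2 (0.35 log units; beyond the scatter) and nothing among the three measured compounds suggests the core of compound 3 would answer differently. The expected step is a 2.3-fold higher number from compound 3 to compound 4 (0.36 log units; beyond the scatter). Compound 4 is expected to give about 93000 nM, estimated to lie between 40000 nM and 220000 nM.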

Compound 4, half-maximal inhibitory concentration: 83000 nM
Compound 4: middle estimate off by 1.1-fold (0.05 log units), on the high side, and the stated range covers the measured number.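

For the compounds shown here, replacing bromo with fluoro to turn 3-bromophenyl into 3-fluorophenyl gave a 2.0-fold higher number from compound 3 to compound 4 (0.31 log units; beyond the scatter), and in this assay this step matches the one seen earlier on the other core: the same change on two cores in this assay, a 2.3-fold higher number (0.35 log units; beyond the scatter) from compound 1 to compound 2 and a 2.0-fold higher number (0.31 log units; beyond the scatter) from compound 3 to compound 4, 1.1-fold (0.04 log units) apart, within the scatter of two such steps The second change, fluoro in place of hydrogen on an aromatic carbon, gave a 2.2-fold lower number from compound 2 to compound 4 (0.34 log units; beyond the scatter), and it also carried over from one core to the other: the same change on two cores in this assay, a 2.0-fold lower number (0.30 log units; within the scatter) from compound 1 to compound 3 and a 2.2-fold lower number (0.34 log units; beyond the scatter) from compound 2 to compound 4, 1.1-fold (0.04 log units) apart, within the scatter of two such steps Across these four compounds, each change therefore had about the same size whether or not the other was present, but this is only one pair of cores, so it neither shows that the pattern holds on other cores nor explains why the numbers move.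

The compounds shown leave open how a chloro or methoxy group would read in the place of the bromo or fluoro on the phenyl ring. They also leave open whether the same steps would appear with a longer chain in the shared core.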